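The source may hold more compounds than are shown below. What is called first, only, known or untested is meant among the compounds shown, and "the series" means these compounds.

Measured compounds:
compound 1, `COc1cc(C(=O)/C=C/c2ccc(Cl)c(Cl)c2)cc(OC)c1OC` — 44000 nM in a functional assay on L1210 cells (Mus musculus) for cytotoxicity, read by MTT assay, with a stated time of 24 h; a higher number here means a weaker inhibitor, a lower number a stronger inhibitor
compound 2, `COc1cc(C(=O)/C=C/c2c(Cl)cccc2Cl)cc(OC)c1OC` — 50500 nM in this assay

Compound 1 and compound 2 differ only in the placement of the two chlorines, and the step of a 1.1-fold higher number from compound 1 to compound 2 (0.06 log units; within the scatter) leaves them within the scatter of each other, so on the two numbers shown compound 1 stands level with compound 2 rather than apart from it. Compound 3, `COc1cc(C(=O)/C=C/c2ccc(F)cc2)cc(OC)c1OC`, is not yet measured in this assay. Relative to compound 1 the change is 4-fluorophenyl in place of 3,4-dichlorophenyl on a double-bonded chain carbon bound to a double-bonded chain carbon. For the measured compounds named here, the one measured step, a 1.1-fold higher number from compound 1 to compound 2 (0.06 log units; within the scatter), concerns only where the two chlorines sit and says nothing about removing a chlorine or exchanging chlorine for fluorine; it bears on the present step only in showing that the dichlorophenyl pattern itself made no difference beyond the scatter. Going by the values given here, with no direct precedent, the step from compound 1 to compound 3 is expected to be small, estimated at a 1.4-fold higher number from compound 1 to compound 3 (0.13 log units; within the scatter), with a wide range kept around it. Compound 3 is therefore estimated at 60000 nM in this assay, with a range from 25000 nM to 150000 nM.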

Compound 3, half-maximal inhibitory concentration: 46500 nM
Compound 3: the middle estimate sits 1.3-fold (0.11 log units) above what was measured, and the stated range covers the measured number.
By their numbers in this assay, from the lowest: compounds 1, 3 and 2 (each within the scatter of the next).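

In this assay, the exchange of 3,4-dichlorophenyl for 4-fluorophenyl on a double-bonded chain carbon bound to a double-bonded chain carbon gives a 1.1-fold higher number from compound 1 to compound 3 (0.02 log units; within the scatter), and the exchange of 2,6-dichlorophenyl for 4-fluorophenyl gives a 1.1-fold lower number from compound 2 to compound 3 (0.04 log units; within the scatter). The earlier pair covered only where the two chlorines sit, whereas these steps show that going from two chlorines to one fluorine, and from 8 heavy atoms to 7 in the group, also leaves the numbers level at this place, so the three aryl groups shown cannot be ranked. No measurement is at hand that would account for this levelness.

The compounds shown contain only halogen-bearing phenyl groups at this place, so it remains open whether an unsubstituted phenyl, or a phenyl carrying an amine or a carboxylic acid, would give a step beyond the scatter. All three compounds also share the rest of the structure, which leaves open how changes to the shared core, such as removing a methoxy group, would read in this assay.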